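The source may report more compounds than this note shows. Statements on the series, on what has been measured and on what is new or still open speak of the compounds shown alone.

Series notes. In a functional assay on the whole organism (strain Wistar) for inhibition, with Rattus norvegicus as the target, read by paw edema, with a stated time of 3 h, at a dose of 10 mg/kg by the intraperitoneal route (on this read-out higher numbers stand for more inhibition at the one dose given (going by the name of the read-out) and lower numbers for less inhibition), compound 1 `O=C(N/N=C/c1cccc(F)c1)c1cccnc1Nc1cccc(C(F)(F)F)c1` gives 37%. In this assay compound 2 `O=C(N/N=C/c1cccc(Cl)c1)c1cccnc1Nc1cccc(C(F)(F)F)c1` gives 55.2%. In this assay compound 3 `O=C(N/N=C/c1ccc(O)c(O)c1)c1cccnc1Nc1cccc(C(F)(F)F)c1` gives 38.2%. Compound 3 stands second of the three numbers: a number 1.2 percentage points higher from compound 1 to compound 3 (within the scatter) lies within the scatter, whereas a number 17 percentage points lower from compound 2 to compound 3 (beyond the scatter) lies beyond it. Compound 4 `COc1ccc(/C=N/NC(=O)c2cccnc2Nc2cccc(C(F)(F)F)c2)cc1` is not yet measured. The change is 4-methoxyphenyl in place of 3,4-dihydroxyphenyl on a carbon with a double bond to nitrogen. Both earlier steps bear on it, since each also swaps the aryl group on the carbon with a double bond to nitrogen; one was within the scatter and one modest, so a modest step in either direction is possible, and no earlier change matches this one. For compound 4 the expected step is a number 3.8 percentage points higher from compound 3 to compound 4 (within the scatter), giving an estimate of 42% with a range from 28% to 58%.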

Compound 4, a percentage reported as inhibition, in the whole organism at one dose (the size of the read-out at that dose, not a potency): 26.5%
Compound 4: the middle estimate sits 15.5 percentage points above what was measured, and the stated range ends above it.
By their numbers in this assay, from the lowest: compound 4; then compounds 1 and 3 (each within the scatter of the next); then compound 2.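

In this assay, the aryl group on the carbon with a double bond to nitrogen can take the number below both earlier low members: a number 11.7 percentage points lower from compound 3 to compound 4 (beyond the scatter) and a number 10.5 percentage points lower from compound 1 to compound 4 (beyond the scatter). The widest step yet at this position is a number 28.7 percentage points lower from compound 2 to compound 4 (beyond the scatter), so 4-methoxyphenyl gives the lowest number of the series. Nothing available explains why this change lowers the number.

Still open, on these data alone, is whether the methoxy group itself or its place on the ring sets this result. As far as these compounds go, how an aryl group bearing an amine or a carboxylic acid would compare also remains open.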